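The source may report more compounds than this note shows. Statements on the series, on what has been measured and on what is new or still open speak of the compounds shown alone.

Measured in a functional assay on Jurkat cells (Homo sapiens); on this read-out higher numbers stand for weaker inhibition and lower numbers for stronger inhibition:
compound 1 `CC(C)[C@H](NC(=O)COc1cccc2ccccc12)C(=O)N[C@@H](CC(=O)O)C(=O)COc1ccc(-c2ccccc2)cc1`: 87900 nM
compound 2 `CC(C)[C@H](NC(=O)COc1cccc2ccccc12)C(=O)N[C@@H](CC(=O)O)C(=O)COc1cccc(C(F)(F)F)c1`: > 100000 nM (a limit)
compound 3 `CC(C)[C@H](NC(=O)COc1cccc2ccccc12)C(=O)N[C@@H](CC(=O)O)C(=O)COc1ccc(C(F)(F)F)cc1`: > 100000 nM (a limit)

Compound 3 gives > 100000 nM, which is a limit and not a number. It shares (the limit of > 100000 nM in this assay, at which 2 of the 3 values shown sit). Compound 4 `CC(C)[C@H](NC(=O)COc1cccc2ccccc12)C(=O)N[C@@H](CC(=O)O)C(=O)COc1ccc(C(N)=O)cc1` has carbamoyl in place of trifluoromethyl on an aromatic carbon, para to a large group (carbamoyl in place of trifluoromethyl on an aromatic carbon). The nearest measured change is an at least 1.1-fold higher number from compound 1 to compound 3 (0.05 log units; that floor lies within the scatter), which offers only a floor. The step of an at least 1.1-fold higher number from compound 1 to compound 2 (0.05 log units; that floor lies within the scatter) offers another floor, and a step that the two limits leave unreadable from compound 2 to compound 3 adds no size. No step beyond the scatter is therefore expected in this assay, and the expected step is a number no higher from compound 3 to compound 4 (the limit leaves the size open). For compound 4 the estimate is 100000 nM, with an expected range of 30000 nM to 300000 nM.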

Compound 4, half-maximal inhibitory concentration: > 100000 nM
Compound 4: only a limit was reported (the forecaster's own chance of this, stated with the estimate: 70%); the middle value sits exactly at the limit.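

In this assay compound 4 gives > 100000 nM, which is a limit and not a number. Carbamoyl, with a hydrogen-bond donor and acceptor where trifluoromethyl has none, gives no readable value at this place either: the limit of > 100000 nM in this assay, at which 3 of the 4 values shown sit. For the compounds shown here, the only readable step is an at least 1.1-fold higher number from compound 1 to compound 4 (0.05 log units; that floor lies within the scatter), and the other steps that end at the limit cannot be read.

Open, on these data alone, is whether an amine or a carboxylic acid on this aromatic carbon gives a number rather than a limit in this assay. A longer chain at this place leaves the same question open.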